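The source may report more compounds than this note shows. Statements on the series, on what has been measured and on what is new or still open speak of the compounds shown alone.

All three measured compounds were tested in an assay for inhibition of steroid 17-alpha-hydroxylase/17,20 lyase (Homo sapiens), tested at 2 uM; a higher number here means a stronger effect of the compound at the concentration tested, a lower number a weaker effect:

compound 1 `Fc1ccc(-c2ccc3c(-c4cccnc4)cccc3c2)cc1` gives 3%
compound 2 `Fc1ccc(-c2ccc3c(-c4ccncc4)cccc3c2)cc1` gives 28%
compound 3 `COc1ccc2cc(-c3cccc(-c4cccnc4)c3)ccc2c1` gives 4%

Compound 1 and compound 2 share one core. Compound 2 differs from compound 1 by pyridin-4-yl in place of pyridin-3-yl on an aromatic carbon, and this change produced a number 25 percentage points higher from compound 1 to compound 2 (beyond the scatter). Compound 3 has a different core; the difference between the core of compound 3 and the core of compound 1 is not broken down here. In this assay compound 3 and compound 1 give numbers that lie within the usual scatter of each other, while compound 2 stands beyond the scatter above both.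

Compound 4 `COc1ccc2cc(-c3cccc(-c4ccncc4)c3)ccc2c1` has not yet been measured. It differs from compound 3 by pyridin-4-yl in place of pyridin-3-yl on an aromatic carbon. Within the data shown here, this is the same kind of change as the one from compound 1 to compound 2, but the surroundings are not the same: in compound 1 the change sits on an aromatic carbon of a six-membered aromatic ring of carbon only, part of a fused or bridged system of two rings, ortho to a fused ring and meta to a fused ring, whereas in compound 3 it sits on an aromatic carbon of a six-membered aromatic ring of carbon only, meta to a large group. Among the measured compounds shown here, the only direct evidence for the change is a number 25 percentage points higher from compound 1 to compound 2 (beyond the scatter). The core is different, so the uncertainty is wider than for that single step.

For the measured compounds named here, the change is expected to give a step of a number 18 percentage points higher from compound 3 to compound 4 (beyond the scatter), resting on a number 25 percentage points higher from compound 1 to compound 2 (beyond the scatter) as its only precedent. Compound 4 is therefore expected to give about 22% in this assay, with a likely range from 4% to 45%.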

Compound 4, a percentage reported as inhibition, at one concentration (the size of the read-out at that concentration, not a potency): 23%
Compound 4: middle estimate off by 1 percentage points, on the low side, within the range that was stated.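

In this assay, pyridin-4-yl in place of pyridin-3-yl on an aromatic carbon again goes with a higher read-out, with a number 19 percentage points higher from compound 3 to compound 4 (beyond the scatter) on the second core. Set beside the earlier case, the two steps do not differ beyond what repeated measurement allows, so across these four compounds the change carries from one core to the other with the same direction and a comparable size: the same change on two cores in this assay, a number 25 percentage points higher (beyond the scatter) from compound 1 to compound 2 and a number 19 percentage points higher (beyond the scatter) from compound 3 to compound 4, 6 percentage points apart, within the scatter of two such steps. Among these compounds, this rests on only one pair of compounds per core, each read at a single concentration, so it gives no potency, does not show that the step would hold on a third core, and does not explain why the pyridin-4-yl compounds read higher.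

The compounds shown carry only these two pyridinyl groups, which leaves open whether a pyrimidin-5-yl or an imidazolyl ring in the same place would give a higher or lower read-out. As far as these compounds go, every compound on the core of compound 3 also keeps its methoxy group, so it remains open whether the step would survive with a hydroxyl group or an amine there instead.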